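This account rests on a few compounds, and the source may have more. Where it says the series, first, only, none or still open, it means among the compounds named here.

Measured in a functional assay on Caco-2 cells (Homo sapiens) for cytotoxicity, read by MTT assay, with stated times of 6 h and 48 h; on this read-out higher numbers stand for weaker inhibition and lower numbers for stronger inhibition:
compound 1 `Cn1c(/C=C/C(=O)c2ccccc2O)cc(Br)c1Br`: 3160 nM
compound 2 `COc1ccc(OC)c(C(=O)/C=C/c2cc(Br)c(Br)n2C)c1`: >= 100000 nM (a limit of the assay)
compound 3 `Cn1c(/C=C/C(=O)c2ccc(O)cc2O)cc(Br)c1Br`: 3530 nM

Only two of these three results are numbers. In this assay, compound 1 gives 3160 nM, and it stands level with compound 3 within the scatter, with a 1.1-fold higher number from compound 1 to compound 3 (0.05 log units; within the scatter). The third result is different in kind: compound 2 gives >= 100000 nM, which is a limit and not a number.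

Compound 4 `Cn1c(/C=C/C(=O)c2cc(O)ccc2O)cc(Br)c1Br` has not yet been measured. It differs from compound 1 by one change, hydroxy in place of hydrogen on an aromatic carbon, para to a hydroxy group.

Within the data shown here, one measured step bears on this, since compound 3 also arises from compound 1 by hydroxy in place of hydrogen on an aromatic carbon, and that step was a 1.1-fold higher number from compound 1 to compound 3 (0.05 log units; within the scatter). It is a single step of the same kind and does not sit at the same place, so it is thin ground and the range is kept wide. On that step, no change beyond the scatter is expected in this assay. The expected step is a 1.1-fold higher number from compound 1 to compound 4 (0.04 log units; within the scatter). For compound 4 the estimated value is 3500 nM, with an expected range of 1400 nM to 10000 nM.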

Compound 4, half-maximal inhibitory concentration: >= 100000 nM
Compound 4: no number, only a limit; the forecaster's own chance of this, stated with the estimate: 4%; middle value at least 28-fold (1.45 log units) from the limit.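

In this assay, the change of hydroxy in place of hydrogen on an aromatic carbon proves not to be neutral wherever it falls on this ring: placed para to a hydroxy group and meta to a large group, it gives an at least 31-fold higher number from compound 1 to compound 4 (1.50 log units; beyond the scatter). The earlier compounds shown here gave no sign of this, since the same kind of change at the place it takes in compound 3 gave a 1.1-fold higher number from compound 1 to compound 3 (0.05 log units; within the scatter), so the outcome of adding this hydroxy depends on its place on the ring and not on the added group alone. Compound 4 gives a limit and not a number, which means that the step has a lower bound but no measured size: the limit of >= 100000 nM in this assay, at which 2 of the 4 values shown sit.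

The compounds shown leave open how much weaker compound 4 really is, and whether this place rejects any new group or only hydroxy, since neither a fluorine atom nor an amine nor a carboxylic acid appears there. They also leave open whether a group on the shared core outside this ring, such as a longer chain in place of the methyl on the ring nitrogen, would change the result at this place.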